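The source may report more compounds than this note shows. Statements on the series, on what has been measured and on what is new or still open speak of the compounds shown alone.

Measured compounds in the series:

Compound 1, `COc1ccc(OC)c(-c2cc(-c3ccc(C(=O)N(C)C)s3)on2)c1`. In a functional assay on A549 cells (Homo sapiens) for cytotoxicity, read by XTT assay, with a stated time of 72 h (on this read-out lower numbers stand for stronger inhibition and higher numbers for weaker inhibition), compound 1 gives > 30000 nM, which is a limit of the assay and not a number.
Compound 2, `COc1ccc(OC)c(-c2cc(-c3ccc(C(=O)NCC4CC4)s3)on2)c1`. In this assay compound 2 gives > 30000 nM, again a limit of the assay.
Compound 3, `CN(Cc1ccc(F)cc1)C(=O)c1ccc(-c2cc(C3=CC(=O)C=CC3=O)no2)s1`. In this assay compound 3 gives > 30000 nM, also a limit of the assay.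

Compound 3 therefore stands where every measured compound of the series stands: at the limit of > 30000 nM in this assay, at which 3 of the 3 values shown sit, with no number resolved for any of them.

The next compound is compound 4, `COc1ccc(OC)c(-c2cc(-c3ccc(C(=O)N(C)Cc4ccc(F)cc4)s3)on2)c1`. It differs from compound 3 by a group of 10 heavy atoms (8 carbon, 2 oxygen; one six-membered aromatic ring of carbon only) in place of a group of 8 heavy atoms (6 carbon, 2 oxygen; one six-membered non-aromatic ring of carbon only), on an aromatic carbon; the group that enters is the same 2,5-dimethoxyphenyl that compound 1 and compound 2 carry, while the amide of compound 3 is kept.

Among the measured compounds shown here, only one measured step is available, a step that the two limits leave unreadable from compound 1 to compound 2, and it is unreadable since both ends sit at the limit. It bears on compound 4 only in showing that changing the amide did not lift compound 1 or compound 2 out of the limit. For the measured compounds named here, no step touches the change made here directly.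

On this basis no step beyond the scatter is expected in this assay for the move from compound 3 to compound 4, and compound 4 is expected to stay at the limit as well: the expected step is a step that the limit leaves unreadable from compound 3 to compound 4, giving an estimate of 40000 nM with a range from 10000 nM to 150000 nM.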

Compound 4, half-maximal inhibitory concentration: > 30000 nM
Compound 4 ended at the assay's limit; the forecaster's own chance of this, stated with the estimate: 85%; the middle value does not contradict the limit.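

In this assay compound 4 gives > 30000 nM, a limit of the assay and not a number. No step from compound 1, compound 2 or compound 3 to compound 4 can be read, because all four compounds sit together: the limit of > 30000 nM in this assay, at which 4 of the 4 values shown sit.

The compounds shown leave open whether any change to the shared core or the amide gives a resolved value in this assay.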